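Moving a methoxy group on a sulfonamide series

This account rests on a few compounds, and the source may have more. Where it says the series, first, only, none or still open, it means among the compounds named here.

Measured compounds:
- Compound 1, `C=Cc1ccc(S(=O)(=O)Nc2ccc3oc(-c4ccccc4)nc3c2)cc1`: in an assay on isolated protein for inhibition of malate dehydrogenase, mitochondrial (Sus scrofa), with stated times of 45 min and 30 min (on this read-out higher numbers stand for weaker inhibition and lower numbers for stronger inhibition), compound 1 gives > 63000 nM, which is a limit of the assay rather than a number.
- Compound 2, `O=S(=O)(Nc1ccc2oc(-c3ccccc3)nc2c1)c1ccccc1Cl`: in this assay compound 2 gives > 63000 nM, again a limit.
- Compound 3, `COc1ccccc1S(=O)(=O)Nc1ccc2oc(-c3ccccc3)nc2c1`: in this assay compound 3 gives > 63000 nM, also a limit.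

Compound 3 therefore cannot be ranked against the others: all three values sit at the limit of > 63000 nM in this assay, at which 3 of the 3 values shown sit, so no real number separates them. The measured steps a step that the two limits leave unreadable from compound 1 to compound 2, a step that the two limits leave unreadable from compound 1 to compound 3 and a step that the two limits leave unreadable from compound 2 to compound 3 are each unreadable for the same reason, and none of them involves the change now in question.

Compound 4, `COc1ccc(S(=O)(=O)Nc2ccc3oc(-c4ccccc4)nc3c2)cc1`, differs from compound 3 by 4-methoxyphenyl in place of 2-methoxyphenyl on a sulfonyl sulfur. With the three earlier steps unreadable, no direction or size can be taken from them. Since compound 3 in this assay reports only a limit, the most likely outcome is that compound 4 reports a limit as well. The step that the limit leaves unreadable from compound 3 to compound 4 is expected to be none beyond the scatter. Compound 4 is expected to give 100000 nM, within a range from 40000 nM to 300000 nM.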

Compound 4, half-maximal inhibitory concentration: > 63000 nM
Compound 4 gave a limit, no number; the forecaster's own chance of this, stated with the estimate: 85%; the middle value does not contradict the limit.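

No step among compound 1, compound 2, compound 3 and compound 4 can be read, since each reports only a limit, not a number: the limit of > 63000 nM in this assay, at which 4 of the 4 values shown sit.

Still open, on these data alone, is whether 4-methoxyphenyl and 2-methoxyphenyl on the sulfonyl sulfur differ at all in inhibition, since any difference would lie beyond that limit.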